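A few compounds are considered here, and "the series" means these few. Any claim that something is new, unique, unknown or untested is made for them only; others in the source may bear on it.

Working notes on the series. The read-out throughout is an ADME assay on liver for metabolic stability, with Liver microsome (Homo sapiens) as the target, read by LC-MS, using microsomes; on this read-out lower numbers stand for slow clearance and higher numbers for fast clearance. Compound 1 `CC(C)(C)C[C@@H](O)C(=O)N1OCC[C@H]1C(=O)NCc1cc(Cl)ccc1-n1cnnn1` returns < 12 mL.min-1.g-1, which is the limit of < 12 mL.min-1.g-1 in this assay, at which 1 of the 3 values shown sits, rather than a number. Compound 2 `O=C(NCc1cc(Cl)ccc1-n1cnnn1)[C@@H]1CC=NN1C(=O)[C@H](O)c1ccccc1F` gives 16 mL.min-1.g-1 in this assay, and compound 3 `CC(C)(C)OC[C@@H](O)C(=O)N1C[C@@H]2C[C@@H]2[C@H]1C(=O)NCc1cc(Cl)ccc1-n1cnnn1` gives 37 mL.min-1.g-1. Among the two numbers, compound 2 stands lowest; the gap to compound 3, its nearest neighbour, lies beyond the usual scatter, so compound 3 sits higher.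

The next compound to be measured is compound 4 `O=C(NCc1cc(Cl)ccc1-n1cnnn1)[C@@H]1CC=NN1C(=O)[C@H](O)Cc1ccccc1`. Its structure differs from compound 2 in one place: benzyl in place of 2-fluorophenyl on a saturated chain carbon bound to a carbonyl carbon and an oxygen on a saturated carbon.

Within the data shown here, no step between measured compounds is available for this kind of change, so the expectation rests on compound 2 alone. The hydroxy-bearing carbon and the rest of the core are kept; only the aromatic substituent is exchanged. The step from compound 2 to compound 4 is expected to be small and directed toward faster clearance, roughly a 1.5-fold higher number from compound 2 to compound 4 (0.18 log units; within the scatter), though a result within the scatter would not be surprising. For compound 4 the estimate in this assay is 24 mL.min-1.g-1, with a likely range from 12 mL.min-1.g-1 to 50 mL.min-1.g-1.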

Compound 4, intrinsic clearance in microsomes: < 12 mL.min-1.g-1
Compound 4 gave a limit, no number; the forecaster's own chance of this, stated with the estimate: 15%; at least 2.0-fold (0.30 log units) between middle value and limit.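

Compound 4 returns a limit rather than a number in this assay: the limit of < 12 mL.min-1.g-1 in this assay, at which 2 of the 4 values shown sit.

Read as a step, this is an at least 1.3-fold lower number from compound 2 to compound 4 (0.12 log units; that floor lies within the scatter), the first step in the series at this place, on a saturated chain carbon bound to a carbonyl carbon and an oxygen on a saturated carbon. It shows that exchanging 2-fluorophenyl for benzyl at this place, with the rest of the structure kept, does not move the read-out towards faster clearance, something compound 2 alone could not show; how far the read-out moves in the other direction remains unresolved, as only a floor within the scatter can be stated.

The compounds shown leave open whether the change turns on the fluorine or on the added carbon, a question that plain phenyl or 2-fluorobenzyl at this place would separate. They also leave open whether a longer chain such as 2-phenylethyl, or a chain ending in an amine or a carboxylic acid, would stay at the limit of this read-out or give a measurable number.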